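Amide to Sulfonamide Swap on a Shared Core

A few compounds are considered here, and "the series" means these few. Any claim that something is new, unique, unknown or untested is made for them only; others in the source may bear on it.

Of the compounds shown here, two with a shared core have been measured in a functional assay on 143B cells (Homo sapiens) for antiproliferative activity, read by MTT assay, with a stated time of 48 h; a higher number here means a weaker inhibitor, a lower number a stronger inhibitor. Compound 1 `O=C(Nc1cccc(/C=C/C(=O)c2nc3ccccc3[nH]2)c1)c1cccc(Br)c1` gives 4620 nM in this assay. Compound 2 `Cc1ccc(C(=O)Nc2cccc(/C=C/C(=O)c3nc4ccccc4[nH]3)c2)cc1` gives 6560 nM in this assay, the highest of the two numbers; its nearest neighbour is compound 1, and the step of a 1.4-fold higher number from compound 1 to compound 2 (0.15 log units; within the scatter) lies within the scatter. Compound 3 `Cc1ccccc1S(=O)(=O)Nc1cccc(/C=C/C(=O)c2nc3ccccc3[nH]2)c1` has not yet been measured. It differs from compound 2 as follows: (2-methylphenyl)sulfonyl in place of (4-methylphenyl)carbonyl on a nitrogen on an aromatic ring. For the measured compounds named here, no measured step speaks to this kind of change: the only step recorded swaps one aryl group for another on a carbonyl carbon and was small. With nothing pointing in either direction, compound 3 is expected to land near compound 2, and its value in this assay is estimated at 6000 nM, within a range from 2000 nM to 18000 nM. This amounts to an expected step of a 1.1-fold lower number from compound 2 to compound 3 (0.04 log units; within the scatter), which need not exceed the scatter.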

Compound 3, half-maximal inhibitory concentration: 4060 nM
Compound 3: middle estimate off by 1.5-fold (0.17 log units), on the high side, and the stated range covers the measured number.
By their numbers in this assay, from the lowest: compounds 3, 1 and 2 (each within the scatter of the next).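

The nitrogen on the aromatic ring accepts a change of linking group as well as a change of aryl group. In this assay, (2-methylphenyl)sulfonyl in place of (4-methylphenyl)carbonyl gives a 1.6-fold lower number from compound 2 to compound 3 (0.21 log units; within the scatter) and in place of (3-bromophenyl)carbonyl gives a 1.1-fold lower number from compound 1 to compound 3 (0.06 log units; within the scatter), so a sulfonyl stands where the carbonyl stood without a step beyond the scatter. Nothing available explains why the numbers stay so close.

The swap from compound 2 to compound 3 also exchanges 4-methylphenyl for 2-methylphenyl, so these compounds cannot separate the linking group from the placing of the methyl. Going by these compounds, whether this nitrogen would accept an aryl group carrying an amine or a carboxylic acid as readily remains open.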